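A Piperidine Amide Tail Replaced by Tetrahydroisoquinoline

The source may report more compounds than this note shows. Statements on the series, on what has been measured and on what is new or still open speak of the compounds shown alone.

Compound 1 `CC1CCN(C(=O)CN(C)C(=O)c2ccc(S(C)(=O)=O)c([N+](=O)[O-])c2)CC1` was examined in an assay on isolated protein for inhibition of thyroid hormone receptor beta (Homo sapiens), read by fluorescence polarization; a lower number here means a stronger inhibitor, a higher number a weaker inhibitor. In this assay compound 1 gives > 60000 nM, which is a limit of the assay rather than a measured number. Two relatives of compound 1 were tested alongside it. Compound 2 `CN1CCN(C(=O)CNC(=O)c2ccc(S(C)(=O)=O)c([N+](=O)[O-])c2)CC1` gives > 60000 nM in this assay, again a limit and not a number. Compound 3 `CS(=O)(=O)c1ccc(C(=O)N2CCC(C(=O)N(Cc3ccccc3)Cc3ccccc3)CC2)cc1[N+](=O)[O-]` gives > 60000 nM, once more a limit. Among the compounds with values here, because every one of these values is the limit of > 60000 nM in this assay, at which 3 of the 3 values shown sit, compound 1 stands level with its two relatives, and no compound can be called stronger or weaker than another on these numbers.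

Compound 4 `CN(CC(=O)N1CCc2ccccc2C1)C(=O)c1ccc(S(C)(=O)=O)c([N+](=O)[O-])c1` has not yet been measured. It differs from compound 1 in one place: 1,2,3,4-tetrahydroisoquinolin-2-yl in place of 4-methylpiperidin-1-yl on a carbonyl carbon.

Within the data shown here, no step between two measured compounds is available, so there is nothing to show how a change of this kind moves the read-out in this assay. The expectation for this step is therefore none beyond the scatter, with compound 4 most likely remaining at the limit in this assay. Compound 4 is expected to give about 80000 nM, with a range from 20000 nM to 300000 nM. The step this estimate implies, a step that the limit leaves unreadable from compound 1 to compound 4, is expected to stay within the scatter of the assay.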

Compound 4, half-maximal inhibitory concentration: > 60000 nM
Compound 4 was reported as a limit; the forecaster's own chance of this, stated with the estimate: 85%; the middle value lies beyond the limit too.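

In this assay compound 4 gives > 60000 nM, which is a limit of the assay and not a number. No size can be read for the step from compound 1 to compound 4, since both compounds sit at the same limit: the limit of > 60000 nM in this assay, at which 4 of the 4 values shown sit.

The compounds shown leave open which structural change, if any, would bring a measurable value in this assay.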